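Swapping the Amine Tail on Compound 3

A few compounds are considered here, and "the series" means these few. Any claim that something is new, unique, unknown or untested is made for them only; others in the source may bear on it.

Compound 3 `COc1cc2c(Nc3nc4ccc(C(=O)Nc5c(C)cc(C)cc5C)cc4s3)ncnc2cc1OCCCN1CCCCC1C` gives 8800 nM in a functional assay on NCI-H661 cells (Homo sapiens) for cytotoxicity, read by WST assay, with a stated time of 72 h (a higher number here means a weaker inhibitor, a lower number a stronger inhibitor), the second highest of the three numbers shown. Its nearest neighbour is compound 1 `COc1cc2c(Nc3nc4ccc(C(=O)Nc5c(C)cccc5Cl)cc4s3)ncnc2cc1OCCCN1CCCCC1C` at 5300 nM, reached by a 1.7-fold higher number from compound 1 to compound 3 (0.22 log units; within the scatter). Compound 2 `CCN(CC)CCCOc1cc2ncnc(Nc3nc4ccc(C(=O)Nc5c(C)cccc5C)cc4s3)c2cc1OC` gives 66500 nM, a higher number than compound 3 and beyond the scatter. Compound 4 `CCN(CC)CCCOc1cc2ncnc(Nc3nc4ccc(C(=O)Nc5c(C)cc(C)cc5C)cc4s3)c2cc1OC` differs from compound 3 by diethylamino in place of 2-methylpiperidin-1-yl on a saturated chain carbon, three bonds along the chain from an oxygen on an aromatic ring. Among the compounds with values here, no measured pair differs in that place alone: compound 2 and compound 1 differ both in the amine and in the group on the amide-type nitrogen, so their two values only hint that the diethylamino compound carries the higher number. On that hint the step for compound 4 is expected as a 4.5-fold higher number from compound 3 to compound 4 (0.66 log units; beyond the scatter), towards a higher number. Compound 4 is therefore estimated at 40000 nM, within 12000 nM to 130000 nM.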

Compound 4, half-maximal inhibitory concentration: 7300 nM
Compound 4: middle estimate off by 5.5-fold (0.74 log units), on the high side, outside the stated range (below it).
By their numbers in this assay, from the lowest: compounds 1, 4 and 3 (each within the scatter of the next); then compound 2.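

In this assay, within the data shown here, the only pair differing solely in the amine tail shows that diethylamino in place of 2-methylpiperidin-1-yl stays within the scatter (a 1.2-fold lower number from compound 3 to compound 4 (0.08 log units; within the scatter)). The high number of compound 2 thus does not go with diethylamino alone: with that tail kept, methyl in place of hydrogen on an aromatic carbon gives a step beyond the scatter (a 9.1-fold lower number from compound 2 to compound 4 (0.96 log units; beyond the scatter)). No evidence here explains either step.

From the compounds shown here alone, whether a morpholine tail or a longer chain before the amine would stay within the scatter remains open. So does whether diethylamino behaves alike alongside the amide group of compound 1.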